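Shifting the Nitro Group on the Pendant Aryl Ring

The compounds below may be only part of what the source reports. "The series", "measured", "known", "first", "only" and "open" are said of these compounds alone.

Compound 1 `COc1ccc2c(c1)OC(c1ccc([N+](=O)[O-])cc1)C(c1ccccc1)C2=O`: > 2500000 nM
Compound 2 `CCOc1ccc2c(c1)OC(c1cccc([N+](=O)[O-])c1)C(c1ccccc1)C2=O`: 193000 nM

Among the measured compounds shown here, in a functional assay (a lower number here means that less compound is needed, a higher number that more compound is needed for the effect), compound 2 gives 193000 nM, the only finished number so far. Compound 1 reaches only a limit of the assay, > 2500000 nM. Compound 3 `CCOc1ccc2c(c1)OC(c1ccc([N+](=O)[O-])cc1)C(c1ccccc1)C2=O` is still unmeasured; it differs from compound 2 by 4-nitrophenyl in place of 3-nitrophenyl on a saturated ring carbon. No step between measured compounds is shown. Compound 1 also carries the 4-nitrophenyl group and sits at the limit of > 2500000 nM in this assay, at which 1 of the 2 values shown sits, so compound 3 is expected to need more compound than compound 2, quite possibly beyond what the assay can report. The expected step of a 5.2-fold higher number from compound 2 to compound 3 (0.71 log units; beyond the scatter) is large. Compound 3 is estimated at 1000000 nM, between 200000 nM and 5000000 nM.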

Compound 3, half-maximal effective concentration: > 2500000 nM
Compound 3 gave a limit, no number (the forecaster's own chance of this, stated with the estimate: 50%); at least 2.5-fold (0.39 log units) between middle value and limit.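

With the same atoms joined differently, 4-nitrophenyl in place of 3-nitrophenyl on this saturated ring carbon gives an at least 12-fold higher number from compound 2 to compound 3 (1.11 log units; beyond the scatter) in this assay, so where the nitro group sits on the pendant ring matters here. The value of compound 3 is a limit, not a number, so the real step could be larger. The step between compound 1 and compound 3 cannot be read, since both values are limits, and the effect of their differing chains stays hidden.

Still open, as far as these compounds go, is whether an amine or a carboxylic acid in place of the nitro group on this ring would give a lower number than compound 2.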